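This account rests on a few compounds, and the source may have more. Where it says the series, first, only, none or still open, it means among the compounds named here.

In an ADME assay on microsomes from liver (Mus musculus, strain CD-1) for metabolic stability, read by LC-MS, tested at 2 uM (on this read-out lower numbers stand for a shorter-lived compound and higher numbers for a longer-lived compound), compound 1 (`Cn1ccc2ccc(-c3cc(Nc4ccccc4S(=O)(=O)Nc4cncnc4)cc4nccnc34)cc21`) gives 0.683 h, compound 2 (`CN(C)C(=O)c1ccncc1Nc1cc(-c2ccc3ccn(C)c3c2)c2nccnc2c1`) gives 0.35 h, and compound 3 (`Cn1cc(NC(=O)c2ccncc2Nc2cc(-c3ccc4ccn(C)c4c3)c3nccnc3c2)cn1`) gives 0.2 h. Compound 3 therefore shares the low end of these numbers with compound 2, while compound 1 stands clear of it. Compound 4 (`CC(=O)N1CCC(NC(=O)c2ccncc2Nc2cc(-c3ccc4ccn(C)c4c3)c3nccnc3c2)CC1`) keeps everything in compound 3 except the group on the amide-type nitrogen: 1-acetylpiperidin-4-yl in place of 1-methyl-1H-pyrazol-4-yl on an amide-type nitrogen. Among the measured compounds shown here, the only measured step that changes a group on this amide is a 1.8-fold lower number from compound 2 to compound 3 (0.24 log units; within the scatter). That step is small and involves different groups, so it gives only weak guidance, and no change beyond the scatter is expected in this assay. The expected step is a 1.3-fold higher number from compound 3 to compound 4 (0.10 log units; within the scatter). The estimated half-life of compound 4 is 0.25 h, with an expected range of 0.12 h to 0.5 h.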

Compound 4, half-life: 0.117 h
Estimate against measurement, compound 4: 2.1-fold (0.33 log units) above; measured number below the stated range.
By their numbers in this assay, from the lowest: compounds 4, 3, 2 and 1 (each within the scatter of the next, the first and the last beyond it).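

Putting 1-acetylpiperidin-4-yl in place of 1-methyl-1H-pyrazol-4-yl on the amide-type nitrogen gives a 1.7-fold lower number from compound 3 to compound 4 (0.23 log units; within the scatter), so exchanging these two rings stays inside the scatter of this assay. Set against the dimethylamino amide, the same group gives a 3.0-fold lower number from compound 2 to compound 4 (0.48 log units; beyond the scatter), the only step among these three amides that goes beyond the scatter. No measurement shown gives a cause for this. Still open, going by these compounds, is how piperidin-4-yl without its acetyl would read at this nitrogen. A small open chain such as ethyl is equally untested here.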